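A few compounds are considered here, and "the series" means these few. Any claim that something is new, unique, unknown or untested is made for them only; others in the source may bear on it.

In a functional assay on MCF7 cells (Homo sapiens) for antiproliferative activity (on this read-out higher numbers stand for weaker inhibition and lower numbers for stronger inhibition), compound 1 `CC(C)=CCc1cc(C(=O)Nc2cc3ccc(OCCCN4CCCC4)c(C)c3oc2=O)ccc1O` gives 990 nM and compound 2 `CCNCCCOc1ccc2cc(NC(=O)c3ccc(O)c(CC=C(C)C)c3)c(=O)oc2c1C` gives 980 nM as its number, while compound 3 `CCN(C)CCCOc1ccc2cc(NC(=O)c3ccc(O)c(CC=C(C)C)c3)c(=O)oc2c1C` gives 2190 nM as the highest number of the three. Compound 4 `CC(C)=CCc1cc(C(=O)Nc2cc3ccc(OCCCNC(C)C)c(C)c3oc2=O)ccc1O` has the same atoms as compound 3, joined differently (isopropylamino in place of ethyl(methyl)amino on a saturated chain carbon, three bonds along the chain from an oxygen on an aromatic ring). The closest guide is the step with methyl in place of hydrogen on an amine nitrogen (a 2.2-fold higher number from compound 2 to compound 3 (0.35 log units; beyond the scatter)). Compound 4 keeps that hydrogen, as compound 2 does. Compound 1, with pyrrolidin-1-yl, shows a similar gap (a 2.2-fold higher number from compound 1 to compound 3 (0.34 log units; beyond the scatter)). Going by the values given here, no measured compound carries isopropylamino, so this guide is loose. A modest step to a lower number is expected (a 2.0-fold lower number from compound 3 to compound 4 (0.30 log units; within the scatter)). For compound 4 the estimated value is 1100 nM (expected range 520 nM to 2300 nM).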

Compound 4, half-maximal inhibitory concentration: 740 nM
Compound 4: the middle estimate sits 1.5-fold (0.17 log units) above what was measured; measured number inside the range.
By their numbers in this assay, from the lowest: compounds 4, 2 and 1 (each within the scatter of the next); then compound 3.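

In this assay, rearranging the same atoms from ethyl(methyl)amino to isopropylamino gives a 3.0-fold lower number from compound 3 to compound 4 (0.47 log units; beyond the scatter), so at this position the way the atoms are joined matters, not just which atoms are present. Isopropylamino stays within the scatter of ethylamino, with a 1.3-fold lower number from compound 2 to compound 4 (0.12 log units; within the scatter), and of pyrrolidin-1-yl, with a 1.3-fold lower number from compound 1 to compound 4 (0.13 log units; within the scatter). A hydrogen on the amine nitrogen is common to compound 2 and compound 4, but compound 1 goes against that pattern, having no such hydrogen and still sitting level with them.

Nothing shown explains the gap. As far as these compounds go, whether a morpholine or a longer chain would stay level with these three compounds remains open.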